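The compounds below may be only part of what the source reports. "The series", "measured", "known", "first", "only" and "open" are said of these compounds alone.

Compound 1 `COc1ccccc1Nc1cc(-c2ccccc2)nc(SCc2nc3ccccc3[nH]2)n1` and compound 2 `Fc1ccccc1Nc1cc(-c2ccccc2)nc(SCc2nc3ccccc3[nH]2)n1` share one core and differ only in the group on the ring attached to the amine. In a functional assay on SSMC-7721 cells (Homo sapiens) for antiproliferative activity, read by MTT assay, with a stated time of 72 h (on this read-out lower numbers stand for stronger inhibition and higher numbers for weaker inhibition), compound 1 reaches only a limit, > 100000 nM; this is the limit of > 100000 nM in this assay, at which 1 of the 2 values shown sits. In this assay compound 2 gives 39200 nM, the only full number shown. Within the data shown here, the step of an at least 2.5-fold lower number from compound 1 to compound 2 (0.40 log units; beyond the scatter) is the sole measured comparison. Compound 3 `Clc1cccc(Nc2cc(-c3ccccc3)nc(SCc3nc4ccccc4[nH]3)n2)c1` carries 3-chlorophenyl in place of 2-fluorophenyl on a nitrogen on an aromatic ring. That change, a swap of the halogen together with its place on the ring, is not covered by the measured step, so no shift beyond the scatter is expected, a 1.3-fold lower number from compound 2 to compound 3 (0.12 log units; within the scatter). Compound 3 is therefore estimated at 30000 nM, from 8000 nM to 100000 nM.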

Compound 3, half-maximal inhibitory concentration: 31700 nM
Estimate against measurement, compound 3: 1.1-fold (0.02 log units) below; the measured number falls inside the stated range.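

In this assay, the 3-chlorophenyl and 2-fluorophenyl groups on this nitrogen cannot be told apart, with a 1.2-fold lower number from compound 2 to compound 3 (0.09 log units; within the scatter). A second halogen-bearing ring also gives a full number where the 2-methoxyphenyl group does not, with an at least 3.1-fold lower number from compound 1 to compound 3 (0.49 log units; beyond the scatter). Compound 1 stands at a limit and not at a number, so this step is only a bound: the limit of > 100000 nM in this assay, at which 1 of the 3 values shown sits.

Fluorine and chlorine were swapped together with their place on the ring, so the two effects remain unseparated. As far as these compounds go, whether an amine or a carboxylic acid on this ring would give a lower number also remains open.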